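The source may hold more compounds than are shown below. What is called first, only, known or untested is meant among the compounds shown, and "the series" means these compounds.

Measured compounds:
compound 1, `Oc1ccc(/C=C/c2cccc(O)c2)cc1`, 1.1 ug/mL
compound 2, `COc1ccccc1/C=C/c1ccccc1O`, 15 ug/mL
compound 3, `Nc1cccc(/C=C/c2ccc(O)cc2)c1`, 7 ug/mL

In an ADME assay on HEK293 cells (Homo sapiens) for inhibition, read by MTT assay, with a stated time of 2 days (on this read-out lower numbers stand for stronger inhibition and higher numbers for weaker inhibition), compound 1 gives 1.1 ug/mL and compound 3 gives 7 ug/mL. The step between them, a 6.4-fold higher number from compound 1 to compound 3 (0.80 log units; beyond the scatter), comes from one change: amino in place of hydroxy on an aromatic carbon. Compound 2 stands at 15 ug/mL, the highest of the three numbers, and the difference between its core and the core of compound 1 is not broken down here.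

Compound 4, `COc1ccccc1/C=C/c1ccccc1N`, has not yet been measured in this assay. It differs from compound 2 by amino in place of hydroxy on an aromatic carbon. Among the compounds with values here, this is the same kind of change as the one from compound 1 to compound 3, though not the same: in compound 1 the place was meta to a group of 9 heavy atoms, while in compound 2 it is ortho to a large group.

Within the data shown here, only one measured example of this change exists, so the expectation rests on it alone. Compound 4 is expected to give a number higher than compound 2, because the step of a 6.4-fold higher number from compound 1 to compound 3 (0.80 log units; beyond the scatter) moved in that direction. The expected step is a 4.0-fold higher number from compound 2 to compound 4 (0.60 log units; beyond the scatter), taken somewhat smaller than the earlier one since the surroundings of the place differ. Compound 4 is therefore estimated at 60 ug/mL, with a likely range from 20 ug/mL to 150 ug/mL.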

Compound 4, half-maximal inhibitory concentration: 2.1 ug/mL
Beside the measured number, compound 4's estimate is 29-fold (1.46 log units) above it; measured number outside the range, below it.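

In this assay, amino in place of hydroxy on an aromatic carbon gave a 7.1-fold lower number from compound 2 to compound 4 (0.85 log units; beyond the scatter), so on this core the number fell where it had risen on the core of compound 1, and the two steps differ: the same change on two cores in this assay, a 6.4-fold higher number (0.80 log units; beyond the scatter) from compound 1 to compound 3 and a 7.1-fold lower number (0.85 log units; beyond the scatter) from compound 2 to compound 4, 45-fold (1.66 log units) apart, beyond the scatter of two such steps This shows that in this series neither the direction nor the size of the step carried over from one core to the other, so a step read on one core cannot simply be applied to the other. It does not show which difference between the two cores lies behind the reversal, since they differ in more than the changed group, and two pairs cannot tell which direction would hold on any further core.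

The compounds shown leave open whether the reversal follows the place of the change, here ortho to a large group, or the methoxy group carried by compound 2 and compound 4 on their other ring. They also leave open how other groups at the same place would behave, such as a carboxylic acid or an amide, and whether such groups would likewise shift with the core.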